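This account rests on a few compounds, and the source may have more. Where it says the series, first, only, none or still open, it means among the compounds named here.

Measured in a functional assay on Hs-578T cells (Homo sapiens) for cytotoxicity, read by sulforhodamine B assay, with a stated time of 48 h; a lower number here means a stronger inhibitor of growth, a higher number a weaker inhibitor of growth:
- compound 1 `ClCc1ccc(Cn2cnc3c(Cl)ncnc32)cc1`: 38900 nM
- compound 2 `Nc1nc(Cl)c2ncn(Cc3ccc(CCl)cc3)c2n1`: a limit of the assay, > 100000 nM
- compound 3 `ClCc1ccccc1Cn1cnc2c(Cl)ncnc21`: 6600 nM

Compound 3 gives the lowest of the two numbers that are numbers; the difference between its core and the core of compound 1 is not broken down here, the two having the same atoms joined differently. Compound 1 and compound 2 differ by amino in place of hydrogen on an aromatic carbon. In this assay that change gives an at least 2.5-fold higher number from compound 1 to compound 2 (0.41 log units; beyond the scatter). The step is open at its upper end since compound 2 sits at the limit of > 100000 nM in this assay, at which 1 of the 3 values shown sits.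

Compound 4 `Nc1nc(Cl)c2ncn(Cc3ccccc3CCl)c2n1` is not yet measured in this assay. For the measured compounds named here, it differs from compound 3 by amino in place of hydrogen on an aromatic carbon, which is the same change, at the same place, as the one from compound 1 to compound 2. Going by the values given here, only that one earlier step is available to judge it, and it sets a floor rather than a size. On that basis, for compound 4 the expected step is a 3.8-fold higher number from compound 3 to compound 4 (0.58 log units; beyond the scatter), which rests on the earlier step of an at least 2.5-fold higher number from compound 1 to compound 2 (0.41 log units; beyond the scatter) applied from the number of compound 3. Compound 4 is therefore estimated at 25000 nM, with a likely range from 10000 nM to 100000 nM. Compound 4 may, as compound 2 did, return only a limit rather than a number.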

Compound 4, concentration for total growth inhibition: 77600 nM
Compound 4: middle estimate off by 3.1-fold (0.49 log units), on the low side; low and high end bracket the measured number.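

In this assay, amino in place of hydrogen on an aromatic carbon gives a 12-fold higher number from compound 3 to compound 4 (1.07 log units; beyond the scatter), so the change goes with weaker growth inhibition on the core of compound 3, the same direction as on the core of compound 1. The direction therefore carries across the two cores shown, but the size of the step is not shown to carry across them, and neither core sets a size for a further one: the same change on two cores in this assay, an at least 2.5-fold higher number (0.41 log units; beyond the scatter) from compound 1 to compound 2 and a 12-fold higher number (1.07 log units; beyond the scatter) from compound 3 to compound 4; the limit leaves it open whether they differ
For compound 2 the reading is a limit of the assay and not a number: the limit of > 100000 nM in this assay, at which 1 of the 4 values shown sits.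

The compounds shown leave open whether a methylamino group, a hydroxyl group or a fluoro group on that same aromatic carbon would follow amino or part from it. They also leave open how the step would behave with the chloromethyl group replaced by a methyl group or a longer chain, or with the chloro group on the shared core replaced by a methoxy group or an amine.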